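A few compounds are considered here, and "the series" means these few. Any claim that something is new, unique, unknown or untested is made for them only; others in the source may bear on it.

Compound 1 `CC(C)N(Cc1cccc(OCCCCCC(=O)O)c1)C(=O)c1ccc(-c2cccc3ccccc23)cc1` gives > 26000 nM in an ADME assay on HEK293 cells (Homo sapiens) for cytotoxicity, read by CellTiter-Glo and resazurin assay, with a stated time of 72 h (a lower number here means that less compound is needed, a higher number that more compound is needed for the effect), which is a limit of the assay and not a number.
Compound 2 `CC(C)N(Cc1cccc(OCCCCCC(=O)O)c1)C(=O)c1ccc(-c2ccncc2)cc1` gives > 26000 nM in this assay, again a limit of the assay.
Compound 3 `CC(C)N(Cc1cccc(OCCCCCC(=O)O)c1)C(=O)c1ccc(-c2cccc(-c3ccccc3)c2)cc1` gives > 26000 nM in this assay, once more a limit of the assay.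

Compound 3 thus stands at the limit, and it does not stand alone there: the limit of > 26000 nM in this assay, at which 3 of the 3 values shown sit. Among the measured compounds shown here, because of this, the step that the two limits leave unreadable from compound 1 to compound 2, the step that the two limits leave unreadable from compound 1 to compound 3 and the step that the two limits leave unreadable from compound 2 to compound 3 cannot be read; they tell only that the three compounds were not separated by the assay.

Compound 4 `CC(C)N(Cc1cccc(OCCCCCC(=O)O)c1)C(=O)c1ccc(-c2cccc(Oc3ccccc3)c2)cc1` differs from compound 3 in one place: phenoxy in place of phenyl on an aromatic carbon. For the measured compounds named here, none of the measured steps gives a readable size, so there is no basis for expecting a step beyond the scatter in either direction in this assay. What the three measured compounds share is that they all sit at the limit, and compound 4 is expected to behave the same way, most likely reported as a limit again. The step from compound 3 to compound 4 is estimated as a step that the limit leaves unreadable from compound 3 to compound 4. Compound 4 is expected to give about 40000 nM, with a range from 20000 nM to 100000 nM.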

Compound 4, half-maximal effective concentration: > 18700 nM
Compound 4 was reported as a limit (the forecaster's own chance of this, stated with the estimate: 85%); the middle value is on the limit's open side.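

Compound 4, like compound 3, is reported only as a limit, and the step between them in this assay cannot be read. The compounds shown leave open at what concentration any of the four would reach the half-maximal effect in this assay, and whether the groups varied on the shared core differ there at all.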